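Side-chain change from compound 3 to compound 4

The source may report more compounds than this note shows. Statements on the series, on what has been measured and on what is new or still open speak of the compounds shown alone.

In a functional assay on HCT-116 cells (Homo sapiens) for antiproliferative activity, read by sulforhodamine B assay, with a stated time of 72 h (a lower number here means a stronger inhibitor, a higher number a weaker inhibitor), compound 1 (`Cn1ncc(Cl)c1-c1cc(C(=O)N[C@@H]2CN[C@H](CC(=O)O)C[C@H]2c2ccc(Cl)c(Cl)c2)oc1Cl`) gives 4020 nM and compound 2 (`CCC[C@@H]1C[C@@H](c2ccc(Cl)c(Cl)c2)[C@H](NC(=O)c2cc(-c3c(Cl)cnn3C)c(Cl)o2)CN1`) gives 1020 nM while compound 3 (`Cn1ncc(Cl)c1-c1cc(C(=O)N[C@@H]2CN[C@H](CCN3CCCC3)C[C@H]2c2ccc(Cl)c(Cl)c2)oc1Cl`) gives 1940 nM as its number. Compound 3 therefore lies within the scatter of compound 2, and its number is lower than that of compound 1 by just beyond the scatter.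

The change to compound 4 (`Cn1ncc(Cl)c1-c1cc(C(=O)N[C@@H]2CN[C@H](CC(=O)NCCO)C[C@H]2c2ccc(Cl)c(Cl)c2)oc1Cl`) puts (2-hydroxyethyl)carbamoyl in place of (pyrrolidin-1-yl)methyl on a saturated chain carbon bound to a saturated ring carbon.

Within the data shown here, three measured steps bear on this place: a 3.9-fold lower number from compound 1 to compound 2 (0.60 log units; beyond the scatter) and a 2.1-fold lower number from compound 1 to compound 3 (0.32 log units; beyond the scatter) are modest, and a 1.9-fold higher number from compound 2 to compound 3 (0.28 log units; within the scatter) stays within the scatter. Among the measured compounds shown here, no measured compound carries this carbamoyl group, so the expectation rests on that narrow span. A small step or none beyond the scatter is expected in this assay with a slight lean to a higher number, since compound 4 shares a carbonyl at this place with compound 1 at 4020 nM as its value.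

The step expected is a 1.4-fold higher number from compound 3 to compound 4 (0.16 log units; within the scatter) by this estimate. Compound 4 is estimated at 2800 nM with an expected range from 1100 nM to 7000 nM overall.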

Compound 4, half-maximal inhibitory concentration: 670 nM
Compound 4: middle estimate off by 4.2-fold (0.62 log units), on the high side, and the stated range ends above it.
By their numbers in this assay, from the lowest: compounds 4, 2 and 3 (each within the scatter of the next, the first and the last beyond it); then compound 1.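

In this assay, (2-hydroxyethyl)carbamoyl in place of (pyrrolidin-1-yl)methyl gives a 2.9-fold lower number from compound 3 to compound 4 (0.46 log units; beyond the scatter), and (2-hydroxyethyl)amino in place of hydroxy on a carbonyl carbon gives a 6.0-fold lower number from compound 1 to compound 4 (0.78 log units; beyond the scatter), so a carbonyl at this place does not by itself go with the high number of compound 1. Against ethyl the result is a 1.5-fold lower number from compound 2 to compound 4 (0.18 log units; within the scatter), within the scatter, so the amide side chain and the ethyl of compound 2 cannot be told apart in this assay. Nothing at hand accounts for these steps.

Open, from the compounds shown here alone, is whether the terminal hydroxy or the amide itself carries the step from the carboxylic acid, which an unsubstituted carbamoyl or a (2-methoxyethyl)carbamoyl group at this place would separate. Also open, going by these compounds, is whether a longer hydroxyalkyl chain on the amide nitrogen keeps the number of compound 4 670 nM.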